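This account rests on a few compounds, and the source may have more. Where it says the series, first, only, none or still open, it means among the compounds named here.

compound 1, `Clc1cccc(N2CCN(c3ncnc4[nH]ncc34)CC2)c1`: 107 nM
compound 2, `Cc1ccc(Cl)cc1N1CCN(c2ncnc3[nH]ncc23)CC1`: 13 nM

In an assay for inhibition of ribosomal protein S6 kinase beta-1 variant D18H,T412E (Homo sapiens), read by a luciferase reporter and chemiluminescence, with a stated time of 3 h (on this read-out higher numbers stand for weaker inhibition and lower numbers for stronger inhibition), compound 2 holds the lowest of the two numbers. Within the data shown here, the only measured step, an 8.2-fold lower number from compound 1 to compound 2 (0.92 log units; beyond the scatter), came from a methyl in place of hydrogen on an aromatic carbon elsewhere in the molecule, not at the site now changed. Compound 3, `Cc1ccc(Cl)cc1N1CCN(c2ncnc3[nH]nc(C)c23)CC1`, differs from compound 2 by methyl in place of hydrogen on an aromatic carbon. Among the measured compounds shown here, since the one measured step sits at another place, it bears only loosely on this change, and compound 3 is expected to move by no more than a 1.4-fold higher number from compound 2 to compound 3 (0.14 log units; within the scatter), a step within the scatter. Compound 3 is therefore estimated at 18 nM, in the range 5 nM to 70 nM.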

Compound 3, half-maximal inhibitory concentration: 9 nM
Estimate against measurement, compound 3: 2.0-fold (0.30 log units) above; the measured number falls inside the stated range.
By their numbers in this assay, from the lowest: compounds 3 and 2 (each within the scatter of the next); then compound 1.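

In this assay, methyl in place of hydrogen on an aromatic carbon of the five-membered aromatic ring with 2 nitrogen gives a 1.4-fold lower number from compound 2 to compound 3 (0.16 log units; within the scatter), so this position takes the added methyl with no shift that stands clear of the scatter. The earlier step, made at another place, said nothing about this site. No measurement at hand explains the result. What the compounds shown leave open is whether this carbon tolerates more than a methyl. An ethyl, an amine or a carboxylic acid there could read differently.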